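The source may hold more compounds than are shown below. What is called first, only, known or untested is meant among the compounds shown, and "the series" means these compounds.

Measured so far:
- compound 2 `CC(=O)OC(CCCN1CCN(c2ncc(F)cn2)CC1)c1ccc(F)cc1`: 227 nM
- compound 1 `OC(CCCN1CCN(c2ncc(F)cn2)CC1)(c1ccc(F)cc1)C1CCCCC1`: no result reported

Going by the values given here, compound 2 stands alone on the numbers: in an assay (Cavia porcellus) for displacement of a labelled ligand from Sigma non-opioid intracellular receptor 1 (Homo sapiens) (a lower number here means a stronger inhibitor, a higher number a weaker inhibitor), compound 2 gives 227 nM, and compound 1 contributes no value, so there is no step between measured compounds to lean on and no sense of how much this part of the structure can move the read-out.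

Compound 3 `CC(=O)NC(CCCN1CCN(c2ncc(F)cn2)CC1)c1ccc(F)cc1` is the next entry. It differs from compound 2 in one place: acetamido in place of acetoxy on a saturated chain carbon bound to an aromatic carbon and a saturated chain carbon. The rest of the molecule, including the shared core and the chain, is unchanged.

Among the compounds with values here, with no measured step to calibrate against, the expectation rests on the change itself. Swapping acetoxy for acetamido at the same saturated chain carbon is a small exchange; the step from compound 2 to compound 3 in this assay is expected to be modest, most likely a slight weakening, but not clearly beyond the scatter. Compound 3 is estimated at 350 nM, within a range of 100 nM to 1200 nM, which corresponds to an expected step of a 1.5-fold higher number from compound 2 to compound 3 (0.19 log units; within the scatter).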

Compound 3, half-maximal inhibitory concentration: > 49 nM
Compound 3: only a limit was reported (the forecaster's own chance of this, stated with the estimate: 5%); the middle value lies beyond the limit too.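

In this assay compound 3 is reported only as a limit, > 49 nM. That limit leaves the step from compound 2 to compound 3 unreadable, so it gives no size for this change. The compounds shown leave open whether acetamido in place of acetoxy on this saturated chain carbon moves the read-out at all, and in which direction.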